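Ethyl to Acetyl on the Aromatic Nitrogen of Compound 1

This account rests on a few compounds, and the source may have more. Where it says the series, first, only, none or still open, it means among the compounds named here.

Compound 1 `CCN(c1ccnc(Nc2ccc(C#N)cc2)n1)c1c(F)cc(-c2ccc(C#N)cc2)cc1F` is tested in an ADME assay on MT4 cells (Homo sapiens) for cytotoxicity, read by MTT assay, with a stated time of 5 days (a lower number here means that less compound is tolerated, a higher number that more compound is tolerated), where compound 1 gives 105000 nM, the lowest of the two numbers shown. Compound 2 `CC(C)N(c1ccnc(Nc2ccc(C#N)cc2)n1)c1c(F)cc(-c2ccc(C#N)cc2)cc1F` gives 172000 nM in this assay. For compound 3 `CCC(C)CN(c1ccnc(Nc2ccc(C#N)cc2)n1)c1c(F)cc(-c2ccc(C#N)cc2)cc1F` the result is a limit of the assay, > 255000 nM. The step of a 1.6-fold higher number from compound 1 to compound 2 (0.21 log units; within the scatter) lies within the scatter, while the step of an at least 2.4-fold higher number from compound 1 to compound 3 (0.38 log units; beyond the scatter) goes beyond it, reaching (the limit of > 255000 nM in this assay, at which 1 of the 3 values shown sits); the step of an at least 1.4-fold higher number from compound 2 to compound 3 (0.17 log units; that floor lies within the scatter) has its floor within the scatter. Compound 4 `CC(=O)N(c1ccnc(Nc2ccc(C#N)cc2)n1)c1c(F)cc(-c2ccc(C#N)cc2)cc1F` differs from compound 1 by acetyl in place of ethyl on a nitrogen on an aromatic ring. Within the data shown here, no measured step places an acetyl on that nitrogen, so these steps bear only loosely on the change; larger alkyls gave similar or higher numbers. Compound 4 is therefore expected to show a step of a 1.1-fold higher number from compound 1 to compound 4 (0.06 log units; within the scatter), with an estimated value of 120000 nM between 50000 nM and 300000 nM.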

Compound 4, half-maximal cytotoxic concentration: > 268000 nM
Compound 4: only a limit was reported (the forecaster's own chance of this, stated with the estimate: 25%); middle value at least 2.2-fold (0.34 log units) from the limit.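

In this assay compound 4 gives only a limit of the assay, > 268000 nM. Acetyl, the only group on this nitrogen that is not a saturated alkyl chain, gives an at least 2.5-fold higher number from compound 1 to compound 4 (0.40 log units; beyond the scatter), and the comparison with isopropyl gives an at least 1.5-fold higher number from compound 2 to compound 4 (0.19 log units; that floor lies within the scatter), so a number beyond that of compound 1 is not confined to alkyl groups such as that of compound 3. The step between compound 3 and compound 4 cannot be read, since both values are limits.

Where either compound truly lies remains open. So does whether an amine or a carboxylic acid on this nitrogen would give a similar number.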